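Hydrazide series: a chloro added to the phenyl ring

A few compounds are considered here, and "the series" means these few. Any claim that something is new, unique, unknown or untested is made for them only; others in the source may bear on it.

Measured so far:
compound 1 `CCOC(=O)c1nnc2n(c1=O)CCN2c1ccc(Cl)c(Cl)c1` — > 100000 nM
compound 2 `NNC(=O)c1nnc2n(c1=O)CCN2c1ccccc1` — > 100000 nM

In a functional assay on SiHa cells (Homo sapiens) for inhibition, read by spectrophotometry and BrdU incorporation, with a stated time of 72 h (a lower number here means a stronger inhibitor, a higher number a weaker inhibitor), compound 1 reaches only the limit of the assay, > 100000 nM. In this assay compound 2 likewise reports only a limit, > 100000 nM. Compound 2 therefore stands on no number at all: both values shown are limits, (the limit of > 100000 nM in this assay, at which 2 of the 2 values shown sit). For the measured compounds named here, no step between measured compounds is available, so nothing is known about how any single change moves this read-out.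

Compound 3 `NNC(=O)c1nnc2n(c1=O)CCN2c1cccc(Cl)c1` differs from compound 2 by chloro in place of hydrogen on an aromatic carbon, meta to a large group; cut one bond further out the difference reads phenyl to 3-chlorophenyl. With compound 2 at a limit, the expected step is a number no higher from compound 2 to compound 3 (the limit leaves the size open), none beyond the scatter. Compound 3 is expected at 100000 nM, between 30000 nM and 300000 nM, most likely again reported as a limit.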

Compound 3, half-maximal inhibitory concentration: 75400 nM
Beside the measured number, compound 3's estimate is 1.3-fold (0.12 log units) above it; the measured number falls inside the stated range.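

In this assay, for the compounds shown here, compound 3 gives the first true number in this hydrazide series, 75400 nM. Chloro in place of hydrogen on an aromatic carbon, meta to a large group, gives an at least 1.3-fold lower number from compound 2 to compound 3 (0.12 log units; that floor lies within the scatter), so this position accepts a chloro with the read-out inside the measurable range, but no gain is established. The true size of the step cannot be read because compound 2 rests on a limit and not on a number: the limit of > 100000 nM in this assay, at which 2 of the 3 values shown sit.

From the compounds shown here alone, whether a methoxy, an amine or a carboxylic acid in place of the chloro on this carbon would move the read-out beyond the scatter stays open. Also open is whether the hydrazide itself contributes to the number seen for compound 3, since no single-change comparison at that group is shown.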